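Solubility series: from compound 3 to compound 4

The source may report more compounds than this note shows. Statements on the series, on what has been measured and on what is new or still open speak of the compounds shown alone.

Three compounds have numbers in a physicochemical assay for solubility, measured as kinetic solubility, with a stated time of 1 h, at pH 7.4; on this read-out higher numbers stand for higher solubility and lower numbers for lower solubility. Compound 1 `O=C(Nc1nc(-c2ccc(Cl)c(Cl)c2)cs1)c1c(F)cccc1F` gives 5000 nM. Compound 2 `CC(=O)Nc1nc(-c2ccc(F)c(Cl)c2)cs1` gives 10000 nM. Compound 3 `CC(=O)N[C@@H](C)C(=O)NC1=NN(c2ccc(Cl)c(Cl)c2)CC1` gives 58000 nM, the highest of the three, and its gaps to compound 2 and to compound 1 both lie beyond the scatter.

Compound 4 `O=C(NC1=NN(c2ccc(Cl)c(Cl)c2)CC1)c1cccnc1F` has not been measured in this assay. Relative to compound 3 the change is 2-fluoropyridin-3-yl in place of 1-acetamidoethyl on a carbonyl carbon. Among the compounds with values here, no step between two measured compounds matches this change, so the expectation rests on the plain numbers: the two measured compounds whose carbonyl carbon carries an aromatic ring, compound 1 with 5000 nM and compound 2 with 10000 nM, sit well under compound 3. On that basis a downward step from compound 3 to compound 4 is expected, of about a 5.8-fold lower number from compound 3 to compound 4 (0.76 log units; beyond the scatter), clearly beyond the scatter. Compound 4 is therefore estimated at 10000 nM in this assay, with a range from 3000 nM to 35000 nM.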

Compound 4, solubility: 13000 nM
The estimate for compound 4 lay 1.3-fold (0.11 log units) below the measured number; measured number inside the range.
By their numbers in this assay, from the lowest: compounds 1, 2 and 4 (each within the scatter of the next, the first and the last beyond it); then compound 3.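

In this assay, the carbonyl carbon on this shared core now has its first change that can be read in one place: 2-fluoropyridin-3-yl in place of 1-acetamidoethyl gives a 4.5-fold lower number from compound 3 to compound 4 (0.65 log units; beyond the scatter) on this read-out. The earlier compounds shown here differ in more than one place, so they could not show that this group alone moves the number beyond the scatter, though the size is modest. No measured evidence bears on the reason for this step.

A single step does not separate what leaves with 1-acetamidoethyl from what enters with 2-fluoropyridin-3-yl. As far as these compounds go, whether a pyridine ring without the fluorine, or a chain carrying an amine or a carboxylic acid on this carbonyl carbon, would give a number nearer that of compound 3 remains open.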